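Bromo in Place of Azetidine: An Expected Further Loss

The source may report more compounds than this note shows. Statements on the series, on what has been measured and on what is new or still open speak of the compounds shown alone.

Compound 1 `O=C(Nc1ccc(-c2cnc3cc(N4CCN(C5CC5)CC4)ccn23)cc1)c1ccc([N+](=O)[O-])o1` gives 1650 nM in a functional assay on MGC-803 cells (Homo sapiens) for antiproliferative activity, read by CCK-8 assay, with a stated time of 72 h; a higher number here means a weaker inhibitor, a lower number a stronger inhibitor. Compound 2 `O=C(Nc1ccc(-c2cnc3cc(N4CCC4)ccn23)cc1)c1ccc([N+](=O)[O-])o1` reaches the limit of > 5000 nM in this assay. Among the measured compounds shown here, the one measured comparison is an at least 3.0-fold higher number from compound 1 to compound 2 (0.48 log units; beyond the scatter), and the limit of > 5000 nM in this assay, at which 1 of the 2 values shown sits, marks where compound 2 stands. Compound 3 `O=C(Nc1ccc(-c2cnc3cc(Br)ccn23)cc1)c1ccc([N+](=O)[O-])o1` differs from compound 2 by bromo in place of azetidin-1-yl on an aromatic carbon. Given an at least 3.0-fold higher number from compound 1 to compound 2 (0.48 log units; beyond the scatter), compound 3 is expected to show a step that the limit leaves unreadable from compound 2 to compound 3, a step not beyond the scatter, and most likely another limit. The estimate for compound 3 is 8000 nM, with a range from 3000 nM to 25000 nM.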

Compound 3, half-maximal inhibitory concentration: 750 nM
Compound 3: the middle estimate sits 11-fold (1.03 log units) above what was measured; measured number below the stated range.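

Bromo reverses the loss seen with azetidin-1-yl, giving an at least 6.6-fold lower number from compound 2 to compound 3 (0.82 log units; beyond the scatter) in this assay. It also improves on 4-cyclopropylpiperazin-1-yl, with a 2.2-fold lower number from compound 1 to compound 3 (0.34 log units; beyond the scatter), so among these compounds this position needs no nitrogen-bearing ring, and compound 3, with bromo, is the strongest of the three. Compound 2 stands only at a limit, so the step from it is a bound and not a measured size: the limit of > 5000 nM in this assay, at which 1 of the 3 values shown sits.

From the compounds shown here alone, it remains open how a chloro, a methoxy or a morpholin-4-yl group would fare at this place. Going by these compounds, whether the order of the three compounds holds on other cell lines also remains open.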